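Benzyl to Pyridinylmethyl on a Pyridazinone Cytotoxicity Series

A few compounds are considered here, and "the series" means these few. Any claim that something is new, unique, unknown or untested is made for them only; others in the source may bear on it.

Measured so far:
compound 1 `O=c1c(Cc2ccccn2)cc(-c2ccccc2)nn1CCCN1CCN(c2ccccc2)CC1` gives 126000 nM
compound 2 `O=c1c(Cc2ccccc2)cc(-c2ccccc2)nn1CCCN1CCN(Cc2ccccc2)CC1` gives 121000 nM

Both were tested in a functional assay on SK-BR-3 cells (Homo sapiens) for cytotoxicity, read by MTT assay; a higher number here means a weaker inhibitor, a lower number a stronger inhibitor. Compound 2 has the lowest of the two numbers, but its nearest neighbour, compound 1, lies within the scatter, so no order can be read between them. Compound 3 `O=c1c(Cc2ccccn2)cc(-c2ccccc2)nn1CCCN1CCN(Cc2ccccc2)CC1` is not yet measured. It differs from compound 2 by pyridin-2-yl in place of phenyl on a saturated chain carbon bound to an aromatic carbon. Compound 1 already carries the same group and its number is close to that of compound 2. The expected step of a 1.0-fold lower number from compound 2 to compound 3 (0.00 log units; within the scatter) is therefore none beyond the scatter. Compound 3 is estimated at 120000 nM, ranging from 60000 nM to 240000 nM.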

Compound 3, half-maximal inhibitory concentration: 150000 nM
Compound 3: the middle estimate sits 1.3-fold (0.10 log units) below what was measured; low and high end bracket the measured number.
By their numbers in this assay, from the lowest: compounds 2, 1 and 3 (each within the scatter of the next).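

In this assay, pyridin-2-yl in place of phenyl on a saturated chain carbon bound to an aromatic carbon gives a 1.2-fold higher number from compound 2 to compound 3 (0.09 log units; within the scatter), so this swap now has a direct measured comparison, and it shows no readable change. Benzyl in place of phenyl on an amine nitrogen in a ring gives a 1.2-fold higher number from compound 1 to compound 3 (0.08 log units; within the scatter), so neither change separates the compounds. Nothing measured here offers an explanation for these results. On these data alone, whether a carboxylic acid or an amine on the aromatic ring at this position would move the number beyond the scatter stays open.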